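This account rests on a few compounds, and the source may have more. Where it says the series, first, only, none or still open, it means among the compounds named here.

Compound 3 `CCC(=O)Nc1ccc(-c2nc3cc(C(F)(F)F)ccc3[nH]2)cc1` carries a propanoylamino group on the shared core. In an ADME assay on MT4 cells (Homo sapiens) for cytotoxicity, read by MTT assay, with a stated time of 96 h (on this read-out higher numbers stand for lower toxicity in this test and lower numbers for higher toxicity in this test), compound 3 gives >= 100000 nM, and this is a limit of the assay rather than a number (the limit of >= 100000 nM in this assay, at which 1 of the 3 values shown sits). Compound 1 `O=C(O)CCC(=O)Nc1ccc(-c2nc3cc(C(F)(F)F)ccc3[nH]2)cc1` gives > 100000 nM in this assay, again only a limit (the limit of > 100000 nM in this assay, at which 1 of the 3 values shown sits). Compound 2 `O=[N+]([O-])c1ccc(-c2nc3cc(C(F)(F)F)ccc3[nH]2)cc1` gives 6000 nM in this assay, a measured number. The step of an at least 16-fold higher number from compound 2 to compound 3 (1.22 log units; beyond the scatter) is large, while the step that the two limits leave unreadable from compound 1 to compound 3 cannot be read because both ends are limits.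

Compound 4 `COc1ccc(-c2nc3cc(C(F)(F)F)ccc3[nH]2)cc1` differs from compound 3 by one change: methoxy in place of propanoylamino on an aromatic carbon. Within the data shown here, no measured compound carries a methoxy group, so none of the steps above bears directly on this change; the only guide is that compound 3 stands at a limit, so a move toward a readable number is the more likely direction of change, if any. On this basis compound 4 is expected to give about 60000 nM in this assay, within a range of 15000 nM to 100000 nM. The expected step of an at least 1.6-fold lower number from compound 3 to compound 4 (0.22 log units; that floor lies within the scatter) is therefore uncertain in size.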

Compound 4, half-maximal cytotoxic concentration: 2000 nM
Estimate against measurement, compound 4: 30-fold (1.48 log units) above; the whole stated range lies above it.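

In this assay, among these compounds, nitro was until now the only group on this aromatic carbon, para to a large group, that gave a readable number, and methoxy is a second, with an at least 50-fold lower number from compound 3 to compound 4 (1.69 log units; beyond the scatter) and an at least 50-fold lower number from compound 1 to compound 4 (1.69 log units; beyond the scatter). Methoxy also goes past nitro, with a 3.0-fold lower number from compound 2 to compound 4 (0.48 log units; beyond the scatter), which gives compound 4 the lowest number and so the highest toxicity in this test among the four compounds. Compound 3 stands at a limit of the assay and not at a number, so the step from it gives only a floor: the limit of >= 100000 nM in this assay, at which 1 of the 4 values shown sits.

From the compounds shown here alone, what an amine, a hydroxyl or an ethoxy group on this carbon would give stays open. Also open, going by these compounds, is whether a longer chain on the oxygen would keep the number low, or whether other carbonyl-bearing chains would match the high limits of compound 1 and compound 3.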